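From isobutyl to tert-butyl on a sulfonamide nitrogen

This account rests on a few compounds, and the source may have more. Where it says the series, first, only, none or still open, it means among the compounds named here.

Measured in a physicochemical assay for solubility, in phosphate buffer, measured as kinetic solubility, with a stated time of 24 h, at pH 7.4; on this read-out higher numbers stand for higher solubility and lower numbers for lower solubility
Compound 1 (`CC(C)CN(Cc1ccc(N2CCC(C#N)CC2)cc1)S(=O)(=O)Cc1ccccc1`): a limit of <= 1000 nM
Compound 2 (`CC(=O)N1CCN(c2ccc(CN(CC(C)C)S(=O)(=O)Cc3ccccc3)cc2)CC1`): a limit of <= 1000 nM

Compound 2 has only a limit and no number (the limit of <= 1000 nM in this assay, at which 2 of the 2 values shown sit). Compound 3 (`CC(=O)N1CCN(c2ccc(CN(C(C)(C)C)S(=O)(=O)Cc3ccccc3)cc2)CC1`) has tert-butyl in place of isobutyl on a sulfonamide nitrogen. Within the data shown here, the only measured step (a step that the two limits leave unreadable from compound 1 to compound 2) has no readable size and lies at another place, so it offers no guide. In this assay no step beyond the usual scatter is therefore expected, in either direction. The expected step is small (a step that the limit leaves unreadable from compound 2 to compound 3). For compound 3 the estimate is 700 nM (expected range 200 nM to 1000 nM), quite possibly reported as a limit again.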

Compound 3, solubility: <= 1000 nM
Compound 3: no number, only a limit; the forecaster's own chance of this, stated with the estimate: 85%; the middle value does not contradict the limit.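

Compound 2 and compound 3 each give only a limit, so no step between them can be read: the limit of <= 1000 nM in this assay, at which 3 of the 3 values shown sit.

On these data alone, how the true values of compound 2 and compound 3 compare, with tert-butyl in place of isobutyl on a sulfonamide nitrogen, stays open.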